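Amide nitrogen variation on the shared core: compound 4

A few compounds are considered here, and "the series" means these few. Any claim that something is new, unique, unknown or untested is made for them only; others in the source may bear on it.

Compound 1 `COc1ccc2c(=O)c(/C=C/C(=O)Nc3cc(C)ccc3C)coc2c1` gives 58400 nM in a functional assay on HeLa cells (Homo sapiens) for inhibition, read by MTT assay, with a stated time of 48 h; a lower number here means a stronger inhibitor, a higher number a weaker inhibitor. Compound 2 `COc1ccc(CNC(=O)/C=C/c2coc3cc(OC)ccc3c2=O)cc1` reaches only the limit > 100000 nM in this assay. Compound 3 `COc1ccc2c(=O)c(/C=C/C(=O)Nc3ccccc3OC)coc2c1` likewise stops at the limit > 100000 nM in this assay, so compound 3 stands at the weak end of the numbers shown, without an exact value. The steps of an at least 1.7-fold higher number from compound 1 to compound 2 (0.23 log units; that floor lies within the scatter) and an at least 1.7-fold higher number from compound 1 to compound 3 (0.23 log units; that floor lies within the scatter) are floors only, and the step that the two limits leave unreadable from compound 2 to compound 3 cannot be read. Compound 4 `CCOc1ccc(NC(=O)/C=C/c2coc3cc(OC)ccc3c2=O)cc1` differs from compound 3 by 4-ethoxyphenyl in place of 2-methoxyphenyl on an amide-type nitrogen. For the measured compounds named here, no measured step on the amide nitrogen leaves a readable number on both sides, so the step of an at least 1.1-fold lower number from compound 3 to compound 4 (0.04 log units; that floor lies within the scatter) is expected to stay within the scatter. Compound 4 is therefore expected near 90000 nM, between 40000 nM and 200000 nM, with a real chance of another limit given (the limit of > 100000 nM in this assay, at which 2 of the 3 values shown sit).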

Compound 4, half-maximal inhibitory concentration: > 100000 nM
Compound 4 ended at the assay's limit (the forecaster's own chance of this, stated with the estimate: 55%); middle value at least 1.1-fold (0.04 log units) away from the limit.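

Moving the alkoxy group to 4-ethoxyphenyl on the amide-type nitrogen adds a third aryl or benzyl group that yields no exact number in this assay, leaving compound 1 with the only exact value: the limit of > 100000 nM in this assay, at which 3 of the 4 values shown sit.

For the compounds shown here, the one readable step is an at least 1.7-fold higher number from compound 1 to compound 4 (0.23 log units; that floor lies within the scatter), a floor only, so 2,5-dimethylphenyl is not set apart from 4-ethoxyphenyl. The steps from compound 3 to compound 4 and from compound 2 to compound 4 cannot be read, as both sides are limits.

From the compounds shown here alone, it remains open whether an amine or a carboxylic acid on this aryl group would give an exact value. Going by these compounds, the effect of changes on the shared core itself is also open.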